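Notes on a 3,4-dihydroxyphenyl swap in the series

The source may report more compounds than this note shows. Statements on the series, on what has been measured and on what is new or still open speak of the compounds shown alone.

Compound 1 `COc1ccc(C2=C(c3ccc(SC)cc3)CC3CCCN3C2=O)cc1C` gives 500 nM in a functional assay on SW-620 cells (Homo sapiens) for cytotoxicity (on this read-out lower numbers stand for stronger inhibition of growth and higher numbers for weaker inhibition of growth), and compound 2 `CSc1ccc(C2=C(c3ccc(C)c(C)c3)C(=O)N3CCCC3C2)cc1` gives 700 nM there, while compound 3 `CSc1ccc(C2=C(c3ccc(F)c(C)c3)C(=O)N3CCCC3C2)cc1` gives 600 nM and so stands within the scatter of both. Compound 4 `CSc1ccc(C2=C(c3ccc(O)c(O)c3)C(=O)N3CCCC3C2)cc1` has 3,4-dihydroxyphenyl in place of 4-fluoro-3-methylphenyl on a double-bonded ring carbon. Three measured swaps at that place bear on this change (a 1.4-fold higher number from compound 1 to compound 2 (0.15 log units; within the scatter); a 1.2-fold higher number from compound 1 to compound 3 (0.08 log units; within the scatter); a 1.2-fold lower number from compound 2 to compound 3 (0.07 log units; within the scatter)) and all lie within the scatter. None of them brings in hydroxyl groups, so they are only a loose guide. For compound 4 the expected step is small and toward a higher number (a 1.7-fold higher number from compound 3 to compound 4 (0.22 log units; within the scatter)). Compound 4 is estimated at 1000 nM (expected range 300 nM to 4000 nM).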

Compound 4, concentration for 50% growth inhibition: 50000 nM
Beside the measured number, compound 4's estimate is 50-fold (1.70 log units) below it; measured number outside the range, above it.
By their numbers in this assay, from the lowest: compounds 1, 3 and 2 (each within the scatter of the next); then compound 4.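

In this assay this place on the double-bonded ring carbon proves sensitive to the group it carries: the earlier groups stay within the scatter of one another, while 3,4-dihydroxyphenyl brings large steps (an 83-fold higher number from compound 3 to compound 4 (1.92 log units; beyond the scatter); a 71-fold higher number from compound 2 to compound 4 (1.85 log units; beyond the scatter); a 100-fold higher number from compound 1 to compound 4 (2.00 log units; beyond the scatter)). Between compound 3 and compound 4 the heavy-atom count of the group is unchanged, and the counted difference lies in the hydrogen-bond donors and acceptors, 0 against 2. Nothing at hand accounts for the size of these steps. Open, going by these compounds, is whether a single hydroxyl gives a step of this size. Also open, on these data alone, is whether 3,4-dimethoxyphenyl at this place reads like compound 1 or like compound 4.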